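Aryl swap at the chain carbon, compound 3 to compound 4

The compounds below may be only part of what the source reports. "The series", "measured", "known", "first", "only" and "open" are said of these compounds alone.

Compound 1 `COC(=O)c1cc(C[C@@H](C)CN2C[C@@H]3CCCC[C@@H]3[C@H](C(=O)N3CCN(c4ccc([N+](=O)[O-])cc4)CC3)C2)cc(C(=O)OC)c1` gives 437 nM in an assay on isolated protein for binding affinity to somatostatin receptor type 1 (Homo sapiens); on this read-out lower numbers stand for tighter binding and higher numbers for weaker binding.
Compound 2 `COC(=O)c1cc(C[C@H](C)CN2C[C@@H]3CCCC[C@@H]3[C@H](C(=O)N3CCN(c4ccc([N+](=O)[O-])cc4)CC3)C2)cc(C(=O)OC)c1` gives 933 nM in this assay.
Compound 3 `Cc1nc2cc(C[C@H](C)CN3C[C@@H]4CCCC[C@@H]4[C@H](C(=O)N4CCN(c5ccc(F)c(F)c5)CC4)C3)ccc2o1` gives 1380 nM in this assay.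

Compound 3 carries the highest number of the three; its gap to compound 2 lies within the scatter, its gap to compound 1 beyond it. Compound 4 `CCOc1ccc(C[C@H](C)CN2C[C@@H]3CCCC[C@@H]3[C@H](C(=O)N3CCN(c4ccc(F)c(F)c4)CC3)C2)cn1` differs from compound 3 by 6-ethoxypyridin-3-yl in place of 2-methyl-1,3-benzoxazol-5-yl on a saturated chain carbon, three bonds along the chain from an amine nitrogen in a ring. Within the data shown here, the only measured single-point step, a 2.1-fold higher number from compound 1 to compound 2 (0.33 log units; beyond the scatter), rests on a change of configuration alone (the fact that compounds 1 and 2 differ only in the configuration as drawn), and no measured step covers an exchange of the aryl group at that chain carbon. The expected step is a 1.0-fold higher number from compound 3 to compound 4 (0.01 log units; within the scatter), nothing beyond the scatter in either direction, with a wide range. Compound 4 is estimated at 1400 nM, expected between 400 nM and 5000 nM.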

Compound 4, dissociation constant: 2340 nM
Compound 4: middle estimate off by 1.7-fold (0.22 log units), on the low side; low and high end bracket the measured number.
By their numbers in this assay, from the lowest: compound 1; then compounds 2, 3 and 4 (each within the scatter of the next, the first and the last beyond it).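

In this assay, among these compounds, 6-ethoxypyridin-3-yl in place of 2-methyl-1,3-benzoxazol-5-yl on the saturated chain carbon gives a 1.7-fold higher number from compound 3 to compound 4 (0.23 log units; within the scatter), the first measured aryl exchange at this position. The two aryl groups therefore cannot be told apart here, although one has a single aromatic ring and the other two. The available evidence concerns configuration only and offers no explanation for this exchange.

Open, from the compounds shown here alone, is whether an amine or a carboxylic acid in place of the aryl group would shift the number beyond the scatter. Also open, going by these compounds, is whether the aryl exchange reads the same with the opposite configuration at the chain carbon.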